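Swapping 1-phenylethyl for isopropyl on an amine nitrogen

The source may report more compounds than this note shows. Statements on the series, on what has been measured and on what is new or still open speak of the compounds shown alone.

Measured in a functional assay on HCT-116 cells (Homo sapiens) for inhibition, read by MTT assay, with a stated time of 72 h; on this read-out higher numbers stand for weaker inhibition and lower numbers for stronger inhibition
compound 1 `COc1cc(Oc2cccc(Nc3ccccc3)c2)cc(OC)c1CNCc1ccccc1` gives 4070 nM
compound 2 `COc1cc(Oc2cccc(Nc3ccccc3)c2)cc(OC)c1CNCc1ccc(C)cc1` gives 13800 nM
compound 3 `COc1cc(Oc2cccc(Nc3ccccc3)c2)cc(OC)c1CN[C@H](C)c1ccccc1` gives > 20000 nM as a limit

Compound 3 has only a limit and no number (the limit of > 20000 nM in this assay, at which 1 of the 3 values shown sits). Compound 4 `COc1cc(Oc2cccc(Nc3ccccc3)c2)cc(OC)c1CNC(C)C` carries isopropyl in place of 1-phenylethyl on an amine nitrogen. Among the measured compounds shown here, no measured step makes this exact change. The nearest are two methyl additions to compound 1, which raised the number in this assay (a 3.4-fold higher number from compound 1 to compound 2 (0.53 log units; beyond the scatter); an at least 4.9-fold higher number from compound 1 to compound 3 (0.69 log units; beyond the scatter)). Compound 4 carries fewer carbons than compound 3, so a loosely sized move towards a lower number, meaning stronger inhibition, is expected. The estimated step is an at least 2.0-fold lower number from compound 3 to compound 4 (0.30 log units; that floor lies within the scatter) (counted from the limit). The estimate for compound 4 is 10000 nM (expected range 3500 nM to 20000 nM).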

Compound 4, half-maximal inhibitory concentration: > 20000 nM
Compound 4: no number, only a limit; the forecaster's own chance of this, stated with the estimate: 30%; middle value at least 2.0-fold (0.30 log units) away from the limit.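

In this assay compound 4 gives > 20000 nM as a limit, not a number. Putting isopropyl on this amine nitrogen gives an at least 4.9-fold higher number from compound 1 to compound 4 (0.69 log units; beyond the scatter) and also an at least 1.4-fold higher number from compound 2 to compound 4 (0.16 log units; that floor lies within the scatter) so, of these two steps, only the first is beyond the scatter, and losing the ring and some carbons did not bring back the inhibition seen with benzyl. The step between compound 3 and compound 4 cannot be read, as both sit at the limit: the limit of > 20000 nM in this assay, at which 2 of the 4 values shown sit. Still open, from the compounds shown here alone, is whether a longer unbranched chain, or a benzyl carrying a carboxylic acid, would beat benzyl here.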